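A few compounds are considered here, and "the series" means these few. Any claim that something is new, unique, unknown or untested is made for them only; others in the source may bear on it.

Measured so far:
compound 1 `O=c1[nH]c(=O)n([C@H]2C[C@H](O)[C@@H](CO)O2)cc1-c1cn(-c2ccc(Br)cc2)nn1` — >= 44000 nM
compound 2 `O=c1[nH]c(=O)n([C@H]2C[C@H](O)[C@@H](CO)O2)cc1-c1cn(-c2ccc(Oc3ccccc3)cc2)nn1` — 130000 nM
compound 3 `O=c1[nH]c(=O)n([C@H]2C[C@H](O)[C@@H](CO)O2)cc1-c1cnnn1-c1ccc(Br)cc1` — > 100000 nM

All three were tested in an ADME assay on HEL cells (Homo sapiens) for cytotoxicity, read by cell counting, with a stated time of 3 days; a higher number here means that more compound is tolerated, a lower number that less compound is tolerated. For compound 1 the value >= 44000 nM is a limit of the measurement. For compound 3 the value > 100000 nM is likewise a limit. Compound 2 gives 130000 nM. The step that the limit leaves unreadable from compound 1 to compound 2, made by phenoxy in place of bromo on an aromatic carbon, stays unreadable because of the limit of >= 44000 nM in this assay, at which 1 of the 3 values shown sits. Compound 4 `O=c1[nH]c(=O)n([C@H]2C[C@H](O)[C@@H](CO)O2)cc1-c1cnnn1-c1ccc(Oc2ccccc2)cc1` is not yet measured; it carries the core of compound 3, and the difference between the two cores is not broken down here. The change phenoxy in place of bromo on an aromatic carbon is the same change as that from compound 1 to compound 2. Since compound 3 sits at the limit of > 100000 nM in this assay, at which 1 of the 3 values shown sits, a high value is expected for compound 4, quite possibly again a limit. The expected step is a step that the limit leaves unreadable from compound 3 to compound 4. Compound 4 is estimated at 130000 nM, between 50000 nM and 300000 nM.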

Compound 4, minimum cytotoxic concentration: > 100000 nM
Compound 4: no number, only a limit (the forecaster's own chance of this, stated with the estimate: 60%); the middle value is on the limit's open side.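

Compound 3 and compound 4 both give a limit rather than a number, so no step between them can be read: the limit of > 100000 nM in this assay, at which 2 of the 4 values shown sit.

The compounds shown leave open whether phenoxy in place of bromo changes the result in this assay on either core.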